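This account rests on a few compounds, and the source may have more. Where it says the series, first, only, none or still open, it means among the compounds named here.

Measured so far in a functional assay on cells (Melanoma cell, Homo sapiens) for cytotoxicity, read by sulforhodamine B assay, with a stated time of 48 h; on this read-out lower numbers stand for stronger inhibition of growth and higher numbers for weaker inhibition of growth:
- compound 1 `COc1ccc(OC)c(-c2cc(-c3ccc(Cl)cc3)nn2-c2ccc(S(=O)(=O)NC(C)=O)cc2)c1`: 28700 nM
- compound 2 `NS(=O)(=O)c1ccc(-n2nc(-c3ccc(Cl)cc3)cc2-c2cc(O)ccc2O)cc1`: 38900 nM

Compound 2 holds the higher of the two numbers in this assay, with compound 1 the nearest; the gap between them sits within the scatter, so the two values show no order. Among the compounds with values here, compound 1 and compound 2 differ in more than one place, and no single step between them is drawn.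

Compound 3 `CC(=O)NS(=O)(=O)c1ccc(-n2nc(-c3ccc(Cl)cc3)cc2-c2cc(O)ccc2O)cc1` is not yet measured. Relative to compound 2 it carries acetyl in place of hydrogen on a sulfonamide nitrogen. The acetylsulfamoyl group is already present in compound 1, where compound 1 in this assay gives 28700 nM, within the scatter of compound 2, although compound 1 also differs elsewhere. Within the data shown here, no measured pair isolates this change, so no direction is expected beyond the scatter. Compound 3 is expected to give about 33000 nM, with a range from 15000 nM to 75000 nM. This estimate means a step of a 1.2-fold lower number from compound 2 to compound 3 (0.07 log units; within the scatter), expected to remain within the usual scatter.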

Compound 3, concentration for total growth inhibition: 60100 nM
Estimate against measurement, compound 3: 1.8-fold (0.26 log units) below; the range from low to high includes it.
By their numbers in this assay, from the lowest: compounds 1, 2 and 3 (each within the scatter of the next, the first and the last beyond it).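

In this assay, acetyl in place of hydrogen on the sulfonamide nitrogen, with the 2,5-dihydroxyphenyl group held fixed, gives a step within the scatter (a 1.5-fold higher number from compound 2 to compound 3 (0.19 log units; within the scatter)), so this change at this position shows no direction in the first single-place reading there. Within the data shown here, with the acetylsulfamoyl group held fixed, 2,5-dihydroxyphenyl in place of 2,5-dimethoxyphenyl on an aromatic carbon gives a modest step beyond the scatter (a 2.1-fold higher number from compound 1 to compound 3 (0.32 log units; beyond the scatter)), the only step that leaves the scatter. Nothing measured on these compounds speaks to the reason for either step.

Open, going by these compounds, is whether the step between the dihydroxyphenyl and dimethoxyphenyl groups reads the same with an unsubstituted sulfamoyl group. Also open, on these data alone, is whether a benzoyl group or a longer acyl chain on the sulfonamide nitrogen would move the number beyond the scatter.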